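The source may hold more compounds than are shown below. What is called first, only, known or untested is meant among the compounds shown, and "the series" means these compounds.

- Compound 1 `Cc1cc(CCC#N)cc(C)c1Oc1cc(Nc2ccc(C#N)cc2)c(N)cc1C(F)(F)F`: 120 mL.min-1.g-1
- Compound 2 `COC(=O)c1cc(N)c(Nc2ccc(C#N)cc2)cc1Oc1c(C)cc(/C=C/C#N)cc1C`: 20 mL.min-1.g-1

In an in vitro ADME assay on microsomes from liver (Homo sapiens) for metabolic stability, tested at 1 uM (a higher number here means faster removal of the compound, a lower number slower removal), compound 2 stands lowest of the two measured compounds at 20 mL.min-1.g-1. Compound 3 `Cc1cc(/C=C/C#N)cc(C)c1Oc1cc(Nc2ccc(C#N)cc2)c(N)cc1C(F)(F)F` is compound 2 with trifluoromethyl in place of methoxycarbonyl on an aromatic carbon. For the measured compounds named here, no measured pair isolates this change, so its size remains uncertain. Compound 1, which also carries trifluoromethyl, gives 120 mL.min-1.g-1, and this points upward. A rise beyond the scatter is expected in this assay, estimated as a 3.0-fold higher number from compound 2 to compound 3 (0.48 log units; beyond the scatter). For compound 3 the expected value is 60 mL.min-1.g-1, with an estimated range of 25 mL.min-1.g-1 to 140 mL.min-1.g-1.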

Compound 3, intrinsic clearance in microsomes: 150 mL.min-1.g-1
Estimate against measurement, compound 3: 2.5-fold (0.40 log units) below; measured number outside the range, above it.
By their numbers in this assay, from the lowest: compound 2; then compounds 1 and 3 (each within the scatter of the next).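

In this assay, trifluoromethyl in place of methoxycarbonyl on an aromatic carbon now stands as a single change, with a 7.5-fold higher number from compound 2 to compound 3 (0.88 log units; beyond the scatter) at this position. 2-Cyanoethenyl in place of 2-cyanoethyl gives a 1.3-fold higher number from compound 1 to compound 3 (0.10 log units; within the scatter), so with trifluoromethyl present, this chain difference does not separate the two compounds. Nothing measured here accounts for the step at the aromatic carbon. The compounds shown leave open whether the step from methoxycarbonyl to trifluoromethyl has the same size with 2-cyanoethyl on the other ring. They also leave open how a carboxylic acid, a primary amide or a methyl group at this position would compare.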